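Benzylidene indanone series: hydroxy for fluoro on the aryl ring

A few compounds are considered here, and "the series" means these few. Any claim that something is new, unique, unknown or untested is made for them only; others in the source may bear on it.

Of the compounds shown here, two have been measured in an assay on isolated protein for inhibition of Amine oxidase [flavin-containing] A (Homo sapiens), read by fluorescence and spectrophotometry, with a stated time of 20 min (on this read-out higher numbers stand for weaker inhibition and lower numbers for stronger inhibition), so far. Compound 1 `O=C1/C(=C/c2ccccc2)Cc2ccc(O)cc21` gives 440 nM. Compound 2 `O=C1/C(=C/c2cccc(F)c2)Cc2cc(O)ccc21` gives 458 nM, which is the highest of the two numbers, although compound 1 sits within the scatter of it. The next compound in the series is compound 3 `O=C1/C(=C/c2cccc(O)c2)Cc2cc(O)ccc21`, which differs from compound 2 by hydroxy in place of fluoro on an aromatic carbon. Among the compounds with values here, no step between measured compounds covers this change, so nothing measured here shows its size; a step of no more than the scatter is expected from compound 2 to compound 3, in either direction. For compound 3 the expected value in this assay is 600 nM, within 200 nM to 1800 nM, meaning a step of a 1.3-fold higher number from compound 2 to compound 3 (0.12 log units; within the scatter).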

Compound 3, half-maximal inhibitory concentration: 1200 nM
For compound 3 the middle estimate is 2.0-fold (0.30 log units) below the measured one, within the range that was stated.
By their numbers in this assay, from the lowest: compounds 1 and 2 (each within the scatter of the next); then compound 3.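

In this assay hydroxy in place of fluoro on this aromatic carbon, meta to a large group, brings a 2.6-fold higher number from compound 2 to compound 3 (0.42 log units; beyond the scatter) and so the position does respond to this change, modestly but beyond the scatter. The swap is of one heavy atom for one, and the entering hydroxy carries a hydrogen-bond donor and acceptor that fluoro does not.

Open, from the compounds shown here alone, is whether methoxy, chloro or an amine at this place would read closer to fluoro or to hydroxy. No measurement at hand bears on the reason for the step.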